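The compounds below may be only part of what the source reports. "The series", "measured", "known", "first", "only" and "open" are said of these compounds alone.

Measured in a functional assay on PC-3 cells (Homo sapiens) for cytotoxicity, read by MTT assay, with a stated time of 72 h; on this read-out lower numbers stand for stronger inhibition of growth and higher numbers for weaker inhibition of growth:
- compound 1 `O=C(Nc1ccc([Se][Se]c2ccc(NC(=O)OCc3ccccc3)cc2)cc1)OCc1ccccc1` gives 100 nM
- compound 2 `CCCCOC(=O)Nc1ccc([Se]C#N)cc1` gives 12400 nM
- compound 3 `Cc1ccc(OC(=O)Nc2ccc([Se][Se]c3ccc(NC(=O)Oc4ccc(C)cc4)cc3)cc2)cc1` gives 4400 nM

Among these three, compound 2 stands at the highest number in this assay, so it is the weakest inhibitor of growth of the set; the nearest number is that of compound 3, and the furthest that of compound 1, both of which differ from compound 2 beyond the scatter.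

Compound 4 `C=CCOC(=O)Nc1ccc([Se]C#N)cc1` differs from compound 2 by vinyl in place of propyl on a saturated chain carbon bound to an oxygen next to a carbonyl group. Within the data shown here, no step between measured compounds that makes a change of this kind is available to compare against. Among the measured compounds shown here, the change is small and stays on the chain far from the rest of the molecule, so it is expected to give no step in this assay beyond the scatter: the step is estimated as a 1.1-fold lower number from compound 2 to compound 4 (0.05 log units; within the scatter). Compound 4 is therefore expected to come in near 11000 nM, with a range from 4000 nM to 30000 nM.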

Compound 4, concentration for 50% growth inhibition: 17600 nM
Beside the measured number, compound 4's estimate is 1.6-fold (0.20 log units) below it, within the range that was stated.
By their numbers in this assay, from the lowest: compound 1; then compound 3; then compounds 2 and 4 (each within the scatter of the next).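

In this assay, vinyl in place of propyl on a saturated chain carbon bound to an oxygen next to a carbonyl group gives a 1.4-fold higher number from compound 2 to compound 4 (0.15 log units; within the scatter) and this lies within the scatter. Among these compounds, this is the first step read at this position, and compound 2 and compound 4 cannot be told apart here. As far as these compounds go, whether a longer chain or a chain ending in an amine would give a step beyond the scatter stays open, as does any single-place link from compound 2 or compound 4 to compound 1 or compound 3. No measurement offered here explains this result.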